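The source may hold more compounds than are shown below. What is called first, only, known or untested is meant among the compounds shown, and "the series" means these compounds.

Working notes on the series. Compound 1 `C/C(=N\NC(=O)COc1cccc2ccccc12)c1ccc(C#N)cc1Br` shares its core with compound 2 `O=C(COc1cccc2ccccc12)N/N=C/c1ccc(O)cc1` and compound 3 `O=C(COc1cccc2ccccc12)N/N=C/c1ccccc1[N+](=O)[O-]`. In an ADME assay on HEL cells (Homo sapiens) for cytotoxicity (a lower number here means that less compound is tolerated, a higher number that more compound is tolerated), compound 1 gives 20 ug/mL. In this assay compound 2 gives 20 ug/mL, and compound 3 gives 20 ug/mL. Compound 1 thus stands level with both at the digits reported, within the scatter of compound 2 and of compound 3 alike.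

Compound 4 `C/C(=N\NC(=O)COc1cccc2ccccc12)c1ccc(O)cc1O` is not yet measured. It differs from compound 1 in one place: 2,4-dihydroxyphenyl in place of 2-bromo-4-cyanophenyl on a carbon with a double bond to nitrogen. Within the data shown here, no measured pair shows what this change does in this assay. Compound 1, compound 2 and compound 3 all sit at one reported level while carrying different groups on the carbon with a double bond to nitrogen; on that basis the expected step is no change at the digits printed from compound 1 to compound 4 (within the scatter), none beyond the scatter. Compound 4 is estimated at 20 ug/mL, with a range from 10 ug/mL to 40 ug/mL.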

Compound 4, minimum cytotoxic concentration: > 100 ug/mL
Compound 4 was reported as a limit; the forecaster's own chance of this, stated with the estimate: 10%; middle value at least 5.0-fold (0.69 log units) away from the limit.
By their numbers in this assay, from the lowest: compounds 1, 2 and 3 (each within the scatter of the next). At a limit, above all of these: compound 4.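

The group on the carbon with a double bond to nitrogen can move the read-out in this assay: 2,4-dihydroxyphenyl in place of 2-bromo-4-cyanophenyl gives an at least 5.0-fold higher number from compound 1 to compound 4 (0.69 log units; beyond the scatter). The reading for compound 4 is a limit of the assay and not a number, so this step has a floor but no known full size: the limit of > 100 ug/mL in this assay, at which 1 of the 4 values shown sits.

This single change cannot separate the part played by the two hydroxyl groups from that of losing the bromine or the nitrile. As far as these compounds go, whether an amine or a carboxylic acid on this phenyl ring would give a similar step remains open.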